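Isopropyl to cyclopropyl on the series' ring nitrogen

The source may report more compounds than this note shows. Statements on the series, on what has been measured and on what is new or still open speak of the compounds shown alone.

compound 1 `CC(C)N1C(=O)COc2ccc(-c3cccc(NS(=O)(=O)c4ccc(F)cc4)c3)cc21`: 26000 nM
compound 2 `O=C1COc2ccc(-c3cnc(Cl)c(NS(=O)(=O)c4ccc(F)cc4)c3)cc2N1c1ccc(Cl)cc1`: 32800 nM

In a functional assay on MCF7 cells (Homo sapiens) for antiproliferative activity, read by MTT assay, with a stated time of 72 h (a higher number here means a weaker inhibitor, a lower number a stronger inhibitor), compound 1 gives 26000 nM. Among the measured compounds shown here, this value lies within the usual scatter of the only other measurement, from compound 2 at 32800 nM, so the two cannot be told apart and no order can be drawn between them. For the measured compounds named here, compound 2 differs from compound 1 in more than one place, so the pair offers no measured step for a single change.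

Compound 3 `O=C1COc2ccc(-c3cccc(NS(=O)(=O)c4ccc(F)cc4)c3)cc2N1C1CC1` is unmeasured. It keeps the core of compound 1, with cyclopropyl in place of isopropyl on an amide-type nitrogen in a ring. The two groups have the same count of heavy atoms, and the series offers no evidence on this exchange. The expectation in this assay is therefore no step beyond the scatter, in either direction, and it is anchored on compound 1 at 26000 nM. The expected change is a 1.1-fold lower number from compound 1 to compound 3 (0.03 log units; within the scatter). For compound 3 the estimated value is 24000 nM, with an expected range of 10000 nM to 55000 nM.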

Compound 3, half-maximal inhibitory concentration: > 40000 nM
Compound 3: only a limit was reported; the forecaster's own chance of this, stated with the estimate: 15%; middle value at least 1.6-fold (0.22 log units) away from the limit.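

In this assay compound 3 carries only a limit, > 40000 nM, and not a number. Cyclopropyl in place of isopropyl on an amide-type nitrogen in a ring gives an at least 1.5-fold higher number from compound 1 to compound 3 (0.18 log units; that floor lies within the scatter), the only measured single-place step shown for this series, and it leaves the true size of the change unfixed. The exchange keeps the count of heavy atoms and adds a three-membered ring, with no gain in activity shown at this position, yet the step is bounded on one side only and could still fall within the scatter or well beyond it: the limit of > 40000 nM in this assay, at which 1 of the 3 values shown sits.

The compounds shown leave open how a longer chain such as n-butyl, or a chain ending in an amine, would read on this nitrogen, and whether any group there moves the value beyond the scatter in either direction. Compound 2 differs from compound 1 and from compound 3 in more than one place, so its 4-chlorophenyl-bearing structure gives no separate reading for this nitrogen.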